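The source may hold more compounds than are shown below. What is called first, only, known or untested is meant among the compounds shown, and "the series" means these compounds.

Of the compounds shown here, three built on one shared core have been tested in a toxicity assay on MT4 cells (Homo sapiens) for cytotoxicity, read by MTT assay, with a stated time of 7 days; on this read-out higher numbers stand for lower toxicity in this test and lower numbers for higher toxicity in this test. Compound 1 `Cc1cc(C)cc(S(=O)(=O)c2c(C(=O)NC3CC4(CCN(S(C)(=O)=O)C4)C3)[nH]c3ccc(Cl)cc23)c1` gives 205000 nM, the highest of the three numbers, so it is the least toxic of them here. Nearest to it stands compound 2 `Cc1cc(C)cc(S(=O)(=O)c2c(C(=O)NC3CC4(C3)CN(Cc3n[nH]c(=O)n3C)C4)[nH]c3ccc(Cl)cc23)c1` with 65600 nM, and furthest stands compound 3 `Cc1cc(C)cc(S(=O)(=O)c2c(C(=O)NC3CC4(CCN(CC(N)=O)CC4)C3)[nH]c3ccc(Cl)cc23)c1` with 3610 nM; both of these gaps lie beyond the usual scatter. The step followed now leads from compound 1 to compound 4 `Cc1cc(C)cc(S(=O)(=O)c2c(C(=O)NC3CC4(CCN(CC(N)=O)C4)C3)[nH]c3ccc(Cl)cc23)c1`, where a single group is exchanged: carbamoylmethyl in place of methylsulfonyl on an amine nitrogen in a ring. Compound 3 already carries a carbamoylmethyl on an amine nitrogen in a ring, though in a larger ring, and its value of 3610 nM points to a large drop. Compound 4 is therefore expected to give 8000 nM, within 2000 nM to 40000 nM, a step of a 26-fold lower number from compound 1 to compound 4 (1.41 log units; beyond the scatter) towards higher toxicity.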

Compound 4, half-maximal cytotoxic concentration: 3700 nM
The estimate for compound 4 lay 2.2-fold (0.33 log units) above the measured number; the range from low to high includes it.
By their numbers in this assay, from the lowest: compounds 3 and 4 (each within the scatter of the next); then compound 2; then compound 1.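

In this assay the exchange of methylsulfonyl for carbamoylmethyl on this amine nitrogen in a ring gives a 55-fold lower number from compound 1 to compound 4 (1.74 log units; beyond the scatter) and so moves towards higher toxicity in this test. For the compounds shown here, this is the only direct reading of a single change at this position, and it is large although both groups hold the same number of heavy atoms. Nothing measured here explains the shift. On these data alone, how a simple amine or a carboxylic acid on this nitrogen would read stays open, as does a longer chain ending in the same amide.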